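A Bromophenyl Variant of the Stronger Binder

The source may report more compounds than this note shows. Statements on the series, on what has been measured and on what is new or still open speak of the compounds shown alone.

Within the data shown here, compound 2 `Cc1ccc(CSc2nc3ccccc3n2CC(=O)O)cc1` gives 220 nM in an assay on HEK293 cells for displacement of a labelled ligand from prostaglandin D2 receptor 2 (Homo sapiens) (on this read-out lower numbers stand for stronger inhibition and higher numbers for weaker inhibition), the lower of the two numbers measured so far; compound 1 `O=C(O)Cn1c(SCCc2ccccc2)nc2ccccc21` gives 881 nM, and the measured step is a 4.0-fold lower number from compound 1 to compound 2 (0.60 log units; beyond the scatter). Compound 3 `O=C(O)Cn1c(SCc2cccc(Br)c2)nc2ccccc21` differs from compound 2 by 3-bromophenyl in place of 4-methylphenyl on a saturated chain carbon bound to a sulfur. Among the measured compounds shown here, the single measured step changes the same position but exchanges a different fragment, so it bears only loosely on this swap; no measured step trades one substituted phenyl for another. A change beyond the scatter is therefore not expected in either direction. Compound 3 is expected at 250 nM, between 100 nM and 600 nM, which would mean a 1.1-fold higher number from compound 2 to compound 3 (0.06 log units; within the scatter).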

Compound 3, half-maximal inhibitory concentration: 370 nM
For compound 3 the middle estimate is 1.5-fold (0.17 log units) below the measured one; the measured number falls inside the stated range.
By their numbers in this assay, from the lowest: compounds 2 and 3 (each within the scatter of the next); then compound 1.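

Exchanging one substituted phenyl for another on a saturated chain carbon bound to a sulfur gives, in this assay, a 1.7-fold higher number from compound 2 to compound 3 (0.23 log units; within the scatter). Two different substituted phenyls thus leave the number within the scatter, while 3-bromophenyl still stands apart from the benzyl of compound 1, with a 2.4-fold lower number from compound 1 to compound 3 (0.38 log units; beyond the scatter). No evidence available here bears on these numbers. The compounds shown leave open whether a phenyl carrying an amine or a carboxylic acid would fit this pattern. They also leave open how an unsubstituted phenyl would compare.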